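A few compounds are considered here, and "the series" means these few. Any claim that something is new, unique, unknown or untested is made for them only; others in the source may bear on it.

Measured compounds:
- compound 1 `N#C[Se]c1ccc(NC(=O)OCc2ccccc2)cc1` gives 3.7% in a physicochemical assay, with a stated time of 180 min, tested at 0.5 mg/mL; a higher number here means more inhibition at the concentration tested (going by the name of the read-out), a lower number less inhibition
- compound 2 `CCCCOC(=O)Nc1ccc([Se][Se]c2ccc(NC(=O)OCCCC)cc2)cc1` gives 36.1% in this assay
- compound 3 `O=C(Nc1ccc([Se][Se]c2ccc(NC(=O)Oc3ccccc3)cc2)cc1)Oc1ccccc1` gives 66.9% in this assay

Compound 1 stands lowest of the three numbers in this assay; the nearest value is that of compound 2, the furthest that of compound 3, both beyond the scatter. Among the measured compounds shown here, compounds 2 and 3 share a different core from compound 1, so no single step links them to it.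

Compound 4 `CCCCCCOC(=O)Nc1ccc([Se]C#N)cc1` differs from compound 1 by one change: pentyl in place of phenyl on a saturated chain carbon bound to an oxygen next to a carbonyl group. For the measured compounds named here, no step of this kind has been measured here. The change leaves the core of compound 1 intact and only exchanges one chain for another, so no step beyond the scatter is expected in this assay, in either direction. For compound 4 the expected step is a number 2.3 percentage points higher from compound 1 to compound 4 (within the scatter). Compound 4 is therefore estimated at 6%, with a range from 0% to 18%.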

Compound 4, a percentage reported as inhibition, at one concentration (the size of the read-out at that concentration, not a potency): > 25%
Compound 4 was reported as a limit; the forecaster's own chance of this, stated with the estimate: 0%; middle value at least 19 percentage points from the limit.
By their numbers in this assay, from the lowest: compound 1; then compound 2; then compound 3.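

This position is not a silent one: with the core of compound 1 held intact, pentyl in place of phenyl on the saturated chain carbon gives a number at least 21.3 percentage points higher from compound 1 to compound 4 (beyond the scatter). The earlier compounds shown here could not show this, since none of them shared a core with compound 1 in a single step. The value of compound 4 is a limit, not a number: the limit of > 25% in this assay, at which 1 of the 4 values shown sits.

From the compounds shown here alone, how large the step truly is remains open. So does whether a longer chain, or a chain ending in an amine or a carboxylic acid, would behave like pentyl at this place.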